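Three Inactive Analogues and a Fourth Awaiting Measurement

The source may report more compounds than this note shows. Statements on the series, on what has been measured and on what is new or still open speak of the compounds shown alone.

Compound 1 `COc1ccc(-c2c[nH]c(=O)n2-c2cc(OC)c(OC)c(OC)c2)cc1OC`, compound 2 `COc1ccc(-c2c[nH]c(=O)n2-c2cc(OC)c(OC)c(OC)c2)cc1[N+](=O)[O-]` and compound 3 `COc1cc(-n2c(-c3ccc([N+](=O)[O-])cc3)cn(C(C)=O)c2=O)cc(OC)c1OC` were each tested in a functional assay on ECa-109 cells (Homo sapiens) for cytotoxicity, read by MTT assay, with a stated time of 48 h; a lower number here means a stronger inhibitor, a higher number a weaker inhibitor. In this assay compound 1 gives > 50000 nM, which is a limit of the assay rather than a number. In this assay compound 2 gives > 50000 nM, likewise a limit. In this assay compound 3 gives > 50000 nM, again a limit. The change from compound 2 to compound 1, (methoxy in place of nitro on an aromatic carbon), leaves a step that the two limits leave unreadable from compound 2 to compound 1. How the core of compound 3 differs from that of compound 2 is not broken down here. Compound 4 `COc1ccc(-c2cn(C(C)=O)c(=O)n2-c2cc(OC)c(OC)c(OC)c2)cc1` has not yet been measured; it differs from compound 3 by methoxy in place of nitro on an aromatic carbon. This is the same kind of change as from compound 2 to compound 1, but not the same: in compound 1 the methoxy sits ortho to a methoxy group and meta to a large group, while in compound 4 it sits para to a large group. Because (the limit of > 50000 nM in this assay, at which 3 of the 3 values shown sit), the step of a number no higher from compound 3 to compound 4 (the limit leaves the size open) is expected to be small, with a limit again likely. Compound 4 is therefore estimated at 50000 nM in this assay.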

Compound 4, half-maximal inhibitory concentration: > 50000 nM
Compound 4 gave a limit, no number; the forecaster's own chance of this, stated with the estimate: 85%; the middle value lies on the limit itself.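

Going by these compounds alone, compound 3 and compound 4 each give only a limit, not a number, in this assay, so no step between them can be read. The picture across the series is the same: the limit of > 50000 nM in this assay, at which 4 of the 4 values shown sit.

The compounds shown leave open how far each one lies from that limit, and whether any change to them would give a readable number.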